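This account rests on a few compounds, and the source may have more. Where it says the series, first, only, none or still open, it means among the compounds named here.

Among the compounds with values here, compound 2 `CCCCN1C(=O)NC(=O)/C1=C\c1ccccc1` gives 6.8% in a functional assay on A549 cells (Homo sapiens) for antiproliferative activity, read by trypan blue exclusion, with a stated time of 72 h, tested at 20 uM (on this read-out lower numbers stand for less inhibition and higher numbers for more inhibition at the one concentration tested (going by the name of the read-out)), the higher of the two numbers measured so far, though compound 1 `O=C1NC(=O)N(Cc2ccccc2)/C1=C/c1ccccc1`, which gives 2.9%, lies within the scatter of it, the step being a number 3.9 percentage points higher from compound 1 to compound 2 (within the scatter). Compound 3 `O=C1NC(=O)N(c2ccccc2)/C1=C/c1ccccc1` differs from compound 2 by phenyl in place of butyl on an amide-type nitrogen in a ring. Within the data shown here, the only measured step bearing on this exchange at the ring nitrogen is a number 3.9 percentage points higher from compound 1 to compound 2 (within the scatter), which stayed within the scatter, and both measured values sit near the bottom of the read-out. Compound 3 is therefore expected to show a step of a number 0.8 percentage points lower from compound 2 to compound 3 (within the scatter), none beyond the scatter. The estimate for compound 3 is 6%, ranging from 0% to 18%.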

Compound 3, a percentage reported as inhibition, at one concentration (the size of the read-out at that concentration, not a potency): 18%
Estimate against measurement, compound 3: 12 percentage points below, within the range that was stated.
By their numbers in this assay, from the lowest: compounds 1 and 2 (each within the scatter of the next); then compound 3.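

In this assay, placing phenyl on the amide-type nitrogen in the ring moves the read-out, with a number 11.2 percentage points higher from compound 2 to compound 3 (beyond the scatter) where butyl leaves and a number 15.1 percentage points higher from compound 1 to compound 3 (beyond the scatter) where benzyl leaves. The exchange of benzyl for butyl had stayed within the scatter, so this position responds to phenyl itself, and the same ring on a saturated chain carbon does not give this result. Nothing shown here accounts for the rise. As far as these compounds go, whether an amine or a carboxylic acid on that phenyl would keep or enlarge the step remains open.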